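A few compounds are considered here, and "the series" means these few. Any claim that something is new, unique, unknown or untested is made for them only; others in the source may bear on it.

Measured compounds:
- compound 1 `CCN(C/C=C/C#CC(C)(C)C)Cc1cccc(OC[Si](C)(C)c2ccc(Br)cc2)c1` gives 210 nM in a functional assay on liver (Sus scrofa) for inhibition of squalene monooxygenase (Homo sapiens), using microsomes; a higher number here means a weaker inhibitor, a lower number a stronger inhibitor
- compound 2 `CCN(C/C=C/C#CC(C)(C)C)Cc1cccc(OC[Si](C)(C)c2ccc(C)cc2)c1` gives 120 nM in this assay
- compound 3 `CCN(C/C=C/C#CC(C)(C)C)Cc1cccc(OC[Si](C)(C)c2cccc(C)c2)c1` gives 3000 nM in this assay

Compound 1 stands second highest of the three numbers; compound 2 sits nearest, with a 1.8-fold lower number from compound 1 to compound 2 (0.24 log units; within the scatter), and compound 3 furthest, with a 14-fold higher number from compound 1 to compound 3 (1.15 log units; beyond the scatter).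

Compound 4 `CCN(C/C=C/C#CC(C)(C)C)Cc1cccc(OC[Si](C)(C)c2ccccc2C(F)(F)F)c1` is not yet measured. The change from compound 1 is 2-(trifluoromethyl)phenyl in place of 4-bromophenyl on a silicon.

Going by the values given here, two measured steps touch the same silicon-bound aryl. Exchanging bromo for methyl on the aromatic carbon, a 1.8-fold lower number from compound 1 to compound 2 (0.24 log units; within the scatter), is within the scatter. Moving the methyl to the other position, a 25-fold higher number from compound 2 to compound 3 (1.40 log units; beyond the scatter) and a 14-fold higher number from compound 1 to compound 3 (1.15 log units; beyond the scatter), is large and beyond the scatter in both cases, so the place of the substituent on this ring matters more than its identity. Among the compounds with values here, no measured compound carries a substituent where the trifluoromethyl of compound 4 sits, so the direction rests only on the finding that leaving the 4-position costs potency. A weaker inhibitor is therefore expected, with wide uncertainty: the estimated step is a 7.1-fold higher number from compound 1 to compound 4 (0.85 log units; beyond the scatter), and compound 4 is expected at 1500 nM, within a range from 300 nM to 8000 nM.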

Compound 4, half-maximal inhibitory concentration: 70 nM
Compound 4: middle estimate off by 21-fold (1.33 log units), on the high side, and the stated range ends above it.
By their numbers in this assay, from the lowest: compounds 4, 2 and 1 (each within the scatter of the next, the first and the last beyond it); then compound 3.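

In this assay, 2-(trifluoromethyl)phenyl on the silicon replaces 4-bromophenyl with a gain in potency (a 3.0-fold lower number from compound 1 to compound 4 (0.48 log units; beyond the scatter)), so a 4-substituted phenyl is not required here. The same group cannot be separated from 4-methylphenyl (a 1.7-fold lower number from compound 2 to compound 4 (0.23 log units; within the scatter)) but stands far from 3-methylphenyl (a 43-fold lower number from compound 3 to compound 4 (1.63 log units; beyond the scatter)), so the loss seen with compound 3 belongs to that group and does not extend to every aryl lacking a 4-substituent. Nothing on hand accounts for this order.

From the compounds shown here alone, whether the result of compound 4 follows the trifluoromethyl or its place on the ring remains open; 2-methylphenyl and 3-(trifluoromethyl)phenyl on the silicon would separate the two. Unsubstituted phenyl on the silicon would show what any of these substituents adds.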